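Compound 2 Gains a Carbonyl on Its Amine Nitrogen

This account rests on a few compounds, and the source may have more. Where it says the series, first, only, none or still open, it means among the compounds named here.

In a functional assay on A549 cells (Homo sapiens) for antiproliferative activity, read by MTT assay, with a stated time of 24 h (on this read-out lower numbers stand for stronger inhibition and higher numbers for weaker inhibition), compound 1 `O=C(NNc1ccccc1Cl)c1ccc(NS(=O)(=O)c2cnc(O)nc2O)cc1` gives 3340 nM. Compound 2 `Cc1ccccc1NNC(=O)c1cccc(NS(=O)(=O)c2cnc(O)nc2O)c1` gives 14200 nM, the higher of the two numbers and weaker than compound 1 by more than the scatter. Compound 3 `Cc1ccccc1NNC(=O)c1ccccc1NS(=O)(=O)c1cnc(O)nc1O` reads > 20000 nM, which is a limit of the assay and not a number. Compound 4 `Cc1ccccc1C(=O)NNC(=O)c1cccc(NS(=O)(=O)c2cnc(O)nc2O)c1` differs from compound 2 by (2-methylphenyl)carbonyl in place of 2-methylphenyl on an amine nitrogen, with (2-methylphenyl)carbonyl in place of 2-methylphenyl on an amine nitrogen. For the measured compounds named here, no measured pair shows this change, so the expectation in this assay is only a modest one. The expected 1.2-fold lower number from compound 2 to compound 4 (0.07 log units; within the scatter) stays within the scatter, with no firm direction. Compound 4 is estimated at 12000 nM, with an expected range from 4000 nM to 35000 nM.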

Compound 4, half-maximal inhibitory concentration: 8010 nM
Beside the measured number, compound 4's estimate is 1.5-fold (0.18 log units) above it; the range from low to high includes it.
By their numbers in this assay, from the lowest: compound 1; then compounds 4 and 2 (each within the scatter of the next). At a limit, above all of these: compound 3.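

In this assay, (2-methylphenyl)carbonyl in place of 2-methylphenyl on this amine nitrogen gives a 1.8-fold lower number from compound 2 to compound 4 (0.25 log units; within the scatter), so this position accepts the added carbonyl without a step beyond the scatter. The earlier compounds shown here differ from one another in more than one place, so they offered no step at this position. Nothing measured here bears on the cause of this step. Going by these compounds, whether a carboxylic acid or an amine on a longer chain at this nitrogen would give a step beyond the scatter remains open. So does the effect of the same change on compound 1.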